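A few compounds are considered here, and "the series" means these few. Any claim that something is new, unique, unknown or untested is made for them only; others in the source may bear on it.

Values in a functional assay on Jurkat cells (Homo sapiens) for inhibition, read by CCK-8 assay, with a stated time of 48 h; a lower number here means a stronger inhibitor of growth, a higher number a weaker inhibitor of growth:
- compound 1 `CN1CCN(c2ccc(Nc3ncc(Cl)c(NCc4ccccc4)n3)nc2)CC1`: > 100000 nM (a limit of the assay, not a number)
- compound 2 `COc1ccc(CNc2nc(Nc3ccc(N4CCN(C)CC4)cn3)ncc2Cl)cc1`: 12900 nM
- compound 3 `Cc1ccc(Nc2nc(Nc3ccc(N4CCN(C)CC4)cn3)ncc2Cl)cc1`: 30900 nM

Not yet measured: compound 4 `Cc1cccc(Nc2nc(Nc3ccc(N4CCN(C)CC4)cn3)ncc2Cl)c1`.

Of the two actual numbers, compound 3 has the higher, at 30900 nM. Compound 4 differs by 3-methylphenyl in place of 4-methylphenyl on a nitrogen on an aromatic ring. Among the compounds with values here, no measured step makes this exact change. The closest are an at least 3.2-fold lower number from compound 1 to compound 3 (0.51 log units; beyond the scatter) and a 2.4-fold higher number from compound 2 to compound 3 (0.38 log units; beyond the scatter), which both change the group on that nitrogen and are only modest in size, though the first is bounded by a limit. A smaller change is therefore expected here, with no clear direction and probably none beyond the scatter in this assay. The estimated step is a 1.2-fold lower number from compound 3 to compound 4 (0.09 log units; within the scatter). Compound 4 is expected at 25000 nM, within an estimated range of 10000 nM to 70000 nM.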

Compound 4, concentration for 50% growth inhibition: 15300 nM
Compound 4: middle estimate off by 1.6-fold (0.21 log units), on the high side; measured number inside the range.
By their numbers in this assay, from the lowest: compounds 2 and 4 (each within the scatter of the next); then compound 3. At a limit, above all of these: compound 1.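

Moving the methyl alone, with the same atoms, changes the result in this assay: a 2.0-fold lower number from compound 3 to compound 4 (0.31 log units; beyond the scatter). This shows that the placement of the methyl on this ring matters, and not only the kind of group on the nitrogen, while a 1.2-fold higher number from compound 2 to compound 4 (0.07 log units; within the scatter) leaves 3-methylphenyl and 4-methoxybenzyl level here. The remaining step, an at least 6.5-fold lower number from compound 1 to compound 4 (0.81 log units; beyond the scatter), is bounded by the limit of compound 1, which is not a number: the limit of > 100000 nM in this assay, at which 1 of the 4 values shown sits.

Open, from the compounds shown here alone, is whether 3-methylphenyl is the better placement only for methyl. Groups such as 3-methoxyphenyl, 3-aminophenyl or 3-carboxyphenyl on that nitrogen would test this.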